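The compounds below may be only part of what the source reports. "The series", "measured", "known", "first", "only" and "open" are said of these compounds alone.

Measured so far:
Compound 1, `CCc1cnc(N2CCC(n3nnc4cc(-c5ccc(S(C)(=O)=O)cc5)ncc43)CC2)nc1`: 21 nM
Compound 2, `CCc1cnc(N2CCC(n3nnc4cc(-c5ccc(S(C)(=O)=O)cc5F)ncc43)CC2)nc1`: 7 nM
Compound 3, `CCNC(=O)c1ccc(-c2cc3nnn(C4CCN(c5ncc(CC)cn5)CC4)c3cn2)c(F)c1`: 15 nM

All three were tested in a functional assay on HEK293 cells for agonist activity at Glucose-dependent insulinotropic receptor (Homo sapiens), read by HTRF and cAMP accumulation, with a stated time of 30 min; a higher number here means that more compound is needed for the effect, a lower number that less compound is needed. Compound 2 differs from compound 1 by one change, (fluoro in place of hydrogen on an aromatic carbon), and this gave a 3.0-fold lower number from compound 1 to compound 2 (0.48 log units; beyond the scatter). Compound 3 carries an ethylcarbamoyl in place of the methylsulfonyl of compound 2, and that exchange gave a 2.1-fold higher number from compound 2 to compound 3 (0.33 log units; beyond the scatter). Compound 3 and compound 1 differ in more than one place, so the difference between the two cores is not broken down here; in this assay compound 3 gives a number close to that of compound 1, within the usual scatter.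

Compound 4, `CCNC(=O)c1ccc(-c2cc3nnn(C4CCN(c5ncc(CC)cn5)CC4)c3cn2)c(F)c1F`, has not yet been measured. It differs from compound 3 by fluoro in place of hydrogen on an aromatic carbon. Going by the values given here, this is the same kind of change as the one from compound 1 to compound 2, but its surroundings differ: in compound 2 the new fluoro sits ortho to a large group and meta to the methylsulfonyl group, while in compound 4 it sits ortho to a fluoro group, ortho to the ethylcarbamoyl group and meta to a large group. Because the earlier step, a 3.0-fold lower number from compound 1 to compound 2 (0.48 log units; beyond the scatter), was modest, the expected step here is a 1.7-fold lower number from compound 3 to compound 4 (0.22 log units; within the scatter), a little smaller because the place is not the same. For compound 4 in this assay the estimate is 9 nM, expected to fall between 4 nM and 25 nM.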

Compound 4, half-maximal effective concentration: 10 nM
The estimate for compound 4 lay 1.1-fold (0.05 log units) below the measured number; the measured number falls inside the stated range.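

In this assay, the fluoro entering ortho to a fluoro group and ortho to an ethylcarbamoyl group gave a 1.5-fold lower number from compound 3 to compound 4 (0.18 log units; within the scatter), so on this core the effect of the change cannot be told apart from the ordinary spread of repeated measurements. Set beside the earlier case, the two steps cannot be told apart either: the same change on two cores in this assay, a 3.0-fold lower number (0.48 log units; beyond the scatter) from compound 1 to compound 2 and a 1.5-fold lower number (0.18 log units; within the scatter) from compound 3 to compound 4, 2.0-fold (0.30 log units) apart, within the scatter of two such steps. Nothing here speaks against carrying this change from one core to the other, but two cases are too few to fix the size of the step, and the new fluoro stands in a different place in each, so the influence of the core cannot be separated from that of the place.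

The compounds shown leave open how the same fluoro would behave with the ethylcarbamoyl group replaced by a methylsulfonyl group, which would separate the role of that group from the role of the place on the ring. They also leave open whether another small group at this place, such as chloro, methyl or methoxy, would give a number like that of fluoro, and whether a carboxylic acid or a longer amide chain in place of the ethylcarbamoyl group would keep the number in this range.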